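Three Limits and a Trichlorophenyl Change

The source may hold more compounds than are shown below. What is called first, only, known or untested is meant among the compounds shown, and "the series" means these compounds.

Compound 1 `N#CC1=C(N)Oc2c(N)cc3nc4ccccc4nc3c2C12C(=O)N(Cc1cnnn1-c1ccccc1Cl)c1ccccc12` gives > 50000 nM in an ADME assay on L02 cells (Homo sapiens) for antiproliferative activity, read by MTT assay, with a stated time of 48 h (a higher number here means a weaker inhibitor, a lower number a stronger inhibitor), which is a limit of the assay rather than a number.
Compound 2 `N#CC1=C(N)Oc2c(N)cc3nc4ccccc4nc3c2C12C(=O)N(Cc1cnnn1-c1ccc(F)c(Cl)c1)c1ccccc12` gives > 50000 nM in this assay, again a limit.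
Compound 3 `N#CC1=C(N)Oc2c(N)cc3nc4ccccc4nc3c2C12C(=O)N(Cc1cnnn1-c1ccc(Cl)cc1[N+](=O)[O-])c1ccccc12` gives > 50000 nM in this assay, also a limit.

Compound 3 therefore stands at the limit of > 50000 nM in this assay, at which 3 of the 3 values shown sit, together with the two other measured compounds. The steps among them, a step that the two limits leave unreadable from compound 1 to compound 2, a step that the two limits leave unreadable from compound 1 to compound 3 and a step that the two limits leave unreadable from compound 2 to compound 3, are all left unreadable by these limits, so no size or direction can be taken from them.

Compound 4 `N#CC1=C(N)Oc2c(N)cc3nc4ccccc4nc3c2C12C(=O)N(Cc1cnnn1-c1c(Cl)cc(Cl)cc1Cl)c1ccccc12` carries the change (2,4,6-trichlorophenyl in place of 4-chloro-2-nitrophenyl on an aromatic nitrogen). Every measured change on that same aromatic nitrogen ended at the limit, so none of them gives a readable step that would point to a change in this assay beyond the scatter for compound 4. The expectation is that compound 4 also rests at the limit. The estimated step from compound 3 is a step that the limit leaves unreadable from compound 3 to compound 4. Compound 4 is expected at 60000 nM, with a range from 20000 nM to 200000 nM.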

Compound 4, half-maximal inhibitory concentration: > 50000 nM
Compound 4: only a limit was reported; the forecaster's own chance of this, stated with the estimate: 85%; the middle value lies beyond the limit too.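

Among these compounds, compound 4 gives only a limit, as do compound 1, compound 2 and compound 3, so no step among them can be read: the limit of > 50000 nM in this assay, at which 4 of the 4 values shown sit.
The compounds shown leave open how far each lies past that limit in this assay, and whether any group on that aromatic nitrogen would give a readable value.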